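The compounds below may be only part of what the source reports. "The series", "measured", "known", "first", "only" and "open" are said of these compounds alone.

In an assay on isolated protein for binding affinity to secreted frizzled-related protein 1 (Homo sapiens), read by fluorescence (on this read-out higher numbers stand for weaker inhibition and lower numbers for stronger inhibition), three compounds have been measured:

Compound 1, `CN(C)CC(=O)N1CCC(NS(=O)(=O)c2cc(S(=O)(=O)c3ccccc3)ccc2C(F)(F)F)CC1`: 300 nM
Compound 2, `O=C(Cn1ccnc1)N1CCC(NS(=O)(=O)c2cc(S(=O)(=O)c3ccccc3)ccc2C(F)(F)F)CC1`: 30 nM
Compound 3, `CC(C)C(=O)N1CCC[C@H]1C(=O)N1CCC(NS(=O)(=O)c2cc(S(=O)(=O)c3ccccc3)ccc2C(F)(F)F)CC1`: 40 nM

Compound 3 stands second highest of the three numbers. Its nearest neighbour is compound 2, and a 1.3-fold higher number from compound 2 to compound 3 (0.12 log units; within the scatter) lies within the scatter, so the two cannot be told apart. Compound 1 is the furthest away: a 7.5-fold lower number from compound 1 to compound 3 (0.88 log units; beyond the scatter), and a 10-fold lower number from compound 1 to compound 2 (1.00 log units; beyond the scatter) is of similar size, both beyond the scatter.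

Compound 4, `O=C([C@@H]1CCCN1C(=O)Nc1ccccc1)N1CCC(NS(=O)(=O)c2cc(S(=O)(=O)c3ccccc3)ccc2C(F)(F)F)CC1`, follows from compound 3 by a single change: anilino in place of isopropyl on a carbonyl carbon. Within the data shown here, none of the measured steps touches this part of the molecule. The steps from compound 1 to compound 2 and to compound 3 concern what is attached to the carbonyl carbon of the shared core, and the step from compound 2 to compound 3 shows that the whole 1-(isopropylcarbonyl)pyrrolidin-2-yl group gives much the same number as (1H-imidazol-1-yl)methyl. Among the measured compounds shown here, there is no measured step that tells what exchanging isopropyl for anilino does in this assay.

Compound 4 is therefore expected to stay close to compound 3, with no change at the digits printed from compound 3 to compound 4 (within the scatter) not going beyond the scatter. The estimate for compound 4 in this assay is 40 nM, with a range from 15 nM to 120 nM.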

Compound 4, half-maximal inhibitory concentration: 20 nM
Compound 4: the middle estimate sits 2.0-fold (0.30 log units) above what was measured; the range from low to high includes it.
By their numbers in this assay, from the lowest: compounds 4, 2 and 3 (each within the scatter of the next); then compound 1.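

In this assay, among these compounds, the exchange of isopropyl for anilino on the carbonyl carbon gives a 2.0-fold lower number from compound 3 to compound 4 (0.30 log units; within the scatter), the first measured step at this position, so the two groups cannot be told apart here. The change is not a small one on paper: 3 heavy atoms, no ring and no hydrogen-bond donor give way to 7 heavy atoms, a six-membered aromatic ring of carbon only and 1 hydrogen-bond donor, and the number still stays within the scatter, which shows that at least this one larger group can stand here, attached through the phenylcarbamoyl unit, without a step beyond the scatter. Nothing available here speaks to why the two groups read alike.

The compounds shown do not separate the ring from the hydrogen-bond donor, and a benzyl group or an N-methylanilino group on the same carbonyl carbon would pull these two apart. From the compounds shown here alone, how far this position stays silent also remains open, since a carboxylic acid or a primary amine carried on the phenyl ring of the anilino group could still give a step beyond the scatter.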